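The compounds below may be only part of what the source reports. "The series", "measured", "known", "first", "only" and "open" are said of these compounds alone.

Of the compounds shown here, three built on one shared core have been tested in a functional assay on A549 cells (Homo sapiens) for antiproliferative activity, read by MTT assay, with a stated time of 48 h; a higher number here means a weaker inhibitor, a lower number a stronger inhibitor. Compound 1 `COc1ccc(-c2nn(-c3ccccc3)cc2C(=O)/C=C\Nc2ccc(F)cc2)cc1` gives 3980 nM. Compound 2 `COc1ccc(-c2nn(-c3ccccc3)cc2C(=O)/C=C\Nc2ccc(Cl)cc2)cc1` gives 2970 nM, and compound 3 `COc1ccc(-c2nn(-c3ccccc3)cc2C(=O)/C=C\Nc2ccc(O)cc2)cc1` gives 2770 nM. Compound 3 has the lowest of the three numbers, but the gaps to the others are slight: a 1.4-fold lower number from compound 1 to compound 3 (0.16 log units; within the scatter) and a 1.1-fold lower number from compound 2 to compound 3 (0.03 log units; within the scatter), each within the scatter, as is a 1.3-fold lower number from compound 1 to compound 2 (0.13 log units; within the scatter).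

Compound 4 `COc1ccc(-c2nn(-c3ccccc3)cc2C(=O)/C=C\Nc2cc(OC)c(OC)c(OC)c2)cc1` has not yet been measured. It differs from compound 3 in one place: 3,4,5-trimethoxyphenyl in place of 4-hydroxyphenyl on an amine nitrogen. Among the measured compounds shown here, none of the measured steps bears directly on this change; they only exchanged one small group on that ring for another, and every one of them stayed within the scatter. They give no ground to expect a shift beyond the scatter in this assay, even though the present change is larger than any of them. Compound 4 is therefore expected to give about 2500 nM in this assay, within a range from 600 nM to 10000 nM. The expected step is a 1.1-fold lower number from compound 3 to compound 4 (0.04 log units; within the scatter), a number kept close to the scatter.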

Compound 4, half-maximal inhibitory concentration: 11200 nM
Estimate against measurement, compound 4: 4.5-fold (0.65 log units) below; the measured number lies above the stated range.
By their numbers in this assay, from the lowest: compounds 3, 2 and 1 (each within the scatter of the next); then compound 4.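

Swapping one small group for another on the ring held by the amine nitrogen stayed within the scatter, but replacing the whole 4-substituted phenyl with 3,4,5-trimethoxyphenyl does not in this assay: a 4.0-fold higher number from compound 3 to compound 4 (0.61 log units; beyond the scatter), a 3.8-fold higher number from compound 2 to compound 4 (0.58 log units; beyond the scatter) and a 2.8-fold higher number from compound 1 to compound 4 (0.45 log units; beyond the scatter). All three steps are modest and point the same way, towards a weaker inhibitor, so this position is not indifferent to the group it carries. Nothing available explains why the number rises.

The entering group differs from the others in several ways at once, so the compounds shown cannot separate the effect of its three methoxy groups from that of losing the 4-substituent. From the compounds shown here alone, how a single methoxy group, an amine or a carboxylic acid on this ring would compare remains open.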